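Oxidation at the sulfur bridge, one step beyond the data

A few compounds are considered here, and "the series" means these few. Any claim that something is new, unique, unknown or untested is made for them only; others in the source may bear on it.

Compound 2 `O=C(Nc1ccccc1C(F)(F)F)c1ccc(Sc2ccc(O)cc2)cc1` is measured in a functional assay on LNCaP cells (Homo sapiens) for antiproliferative activity, read by fluorescence and propidium iodide staining, with a stated time of 96 h (a higher number here means a weaker inhibitor, a lower number a stronger inhibitor), where compound 2 gives 11400 nM. It stands level with compound 1 `O=C(Nc1cc(C(F)(F)F)ccc1C(F)(F)F)c1ccc(Sc2ccc(O)cc2)cc1`, for which compound 1 gives 11400 nM, and the single shown step, no change at the digits printed from compound 1 to compound 2 (within the scatter), lies within the scatter. Compound 3 `O=C(Nc1cccc(C(F)(F)F)c1)c1ccc(Sc2cccc(C(F)(F)F)c2)cc1` completes the set, and compound 3 gives 12500 nM; all three numbers lie within the scatter of one another, so no one of them can be called stronger or weaker.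

The step from compound 2 to compound 4 `O=C(Nc1ccccc1C(F)(F)F)c1ccc([S+]([O-])c2ccc(O)cc2)cc1` is a group of 9 heavy atoms (6 carbon, 2 oxygen, 1 sulfur; one six-membered aromatic ring of carbon only) in place of a group of 8 heavy atoms (6 carbon, 1 oxygen, 1 sulfur; one six-membered aromatic ring of carbon only), on an aromatic carbon. None of the measured steps touches the sulfur-bearing bridge: the only shown step, trifluoromethyl to hydrogen on an aromatic carbon, concerns a different part of the molecule and has no bearing on this change. The data therefore offer no basis for a direction, and the expectation is a step of no more than the scatter, with a widened range to reflect the absence of a precedent. For compound 4 the expected step is a 1.1-fold higher number from compound 2 to compound 4 (0.02 log units; within the scatter), so compound 4 is estimated at 12000 nM, within a range from 4000 nM to 40000 nM.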

Compound 4, half-maximal inhibitory concentration: 62000 nM
Estimate against measurement, compound 4: 5.2-fold (0.71 log units) below; measured number outside the range, above it.
By their numbers in this assay, from the lowest: compounds 1, 2 and 3 (each within the scatter of the next); then compound 4.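

In this assay the step to oxygen on the sulfur bridge is a 5.4-fold higher number from compound 2 to compound 4 (0.74 log units; beyond the scatter) and makes compound 4 a weaker inhibitor than compound 2, the first step among the compounds shown to lie beyond the scatter. The earlier step, hydrogen in place of trifluoromethyl on an aromatic carbon, left the number unchanged at the digits printed, so the sulfur bridge is the only place in this set where a single change is seen to alter the antiproliferative reading, and that single step gives its direction only for this one pair. Nothing available accounts for the loss, and the reason for it remains unknown.

The compounds shown leave open whether the same oxidation would have a similar effect on the core of compound 1, which carries a second trifluoromethyl, or whether the effect is specific to compound 2. They also leave open how the number would respond to other bridges, such as a sulfonyl, a methylene or an ether oxygen, and so whether the step follows from oxygen on sulfur or from any departure from the plain sulfur bridge.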